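A few compounds are considered here, and "the series" means these few. Any claim that something is new, unique, unknown or untested is made for them only; others in the source may bear on it.

For the measured compounds named here, compound 2 `Cc1cccc(NC(=N)N=C(N)N)c1` stands second highest of the three numbers so far in an in vitro assay on NG 108-15 cells for binding affinity to Serotonin 3 (5-HT3) receptor (Homo sapiens) (on this read-out lower numbers stand for stronger inhibition and higher numbers for weaker inhibition), where compound 2 gives 780 nM. Compound 3 `N=C(N)NCc1cccc(Cl)c1` gives 1200 nM in this assay, a number that sits within the scatter of the number for compound 2, so nothing separates the two. Compound 1 `N=C(N)NC(=N)Nc1ccccc1Cl` gives 62 nM, and this gap to compound 2 lies beyond the scatter. Going by the values given here, no pair of measured compounds differs in only one place, so compounds 1 and 3 serve here only as landmarks around compound 2 rather than as a step that could be read.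

Compound 4 `Cc1cccc(NC(=N)N)c1` is reached from compound 2 by one change: one nitrogen atom in place of a group of 4 heavy atoms (1 carbon, 3 nitrogen; no ring), on a carbon with a double bond to nitrogen. Among the compounds with values here, the data hold no measured example of such a change, so the expectation rests on the structures alone. The step from compound 2 to compound 4 is expected to be a 3.2-fold higher number from compound 2 to compound 4 (0.51 log units; beyond the scatter), a loss of binding somewhat beyond the scatter. Compound 4 is estimated at 2500 nM, with a range from 500 nM to 12000 nM.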

Compound 4, inhibition constant: 6520 nM
Compound 4: the middle estimate sits 2.6-fold (0.42 log units) below what was measured; the range from low to high includes it.
By their numbers in this assay, from the lowest: compound 1; then compounds 2 and 3 (each within the scatter of the next); then compound 4.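

In this assay, for the compounds shown here, putting amino in place of the group of 4 heavy atoms, on the carbon with a double bond to nitrogen, gives an 8.4-fold higher number from compound 2 to compound 4 (0.92 log units; beyond the scatter), the first step in this set that can be read. Going by these compounds alone, the step lies beyond the scatter, so on this core the group of 4 heavy atoms cannot be cut back to amino without a loss of binding, something the earlier compounds, which served only as landmarks, could not show. Nothing at hand gives a measured reason for this loss.

As far as these compounds go, whether an intermediate replacement at the same place, such as a methylamino or an acetyl group, would keep the lower number remains open. From the compounds shown here alone, it is also open whether the same change would cost as much on the core of compound 1, which carries chloro rather than methyl.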